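Replacing the 3-Hydroxyphenyl Group of Compound 1

The compounds below may be only part of what the source reports. "The series", "measured", "known", "first", "only" and "open" are said of these compounds alone.

Compound 1 `O=C(CCCCCCc1ccccc1)c1ncc(-c2cccc(O)c2)o1`: 50 nM
Compound 2 `O=C(CCCCCCc1ccccc1)c1ncc(-c2ccc([N+](=O)[O-])cc2)o1`: 50 nM
Compound 3 `N#Cc1ccc(-c2cnc(C(=O)CCCCCCc3ccccc3)o2)cc1`: 40 nM

These three compounds share one core and one side chain and differ only in the aromatic group attached to an aromatic carbon of that core. In an assay (Rattus norvegicus) for inhibition of Fatty-acid amide hydrolase 1 (Homo sapiens) (on this read-out higher numbers stand for weaker inhibition and lower numbers for stronger inhibition), compound 1 gives 50 nM, compound 2 gives 50 nM and compound 3 gives 40 nM. Compound 1 thus gives the same number as compound 2, the two together being the highest of the three, while compound 3 lies a 1.3-fold lower number from compound 1 to compound 3 (0.10 log units; within the scatter) away from compound 1.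

Compound 4 `NS(=O)(=O)c1ccc(-c2cnc(C(=O)CCCCCCc3ccccc3)o2)s1` has not been measured. It differs from compound 1 in one place: 5-sulfamoylthiophen-2-yl in place of 3-hydroxyphenyl on an aromatic carbon. Among the measured compounds shown here, three measured steps bear on this change, all of them swaps of the aromatic group at the same carbon: no change at the digits printed from compound 1 to compound 2 (within the scatter), a 1.3-fold lower number from compound 1 to compound 3 (0.10 log units; within the scatter) and a 1.3-fold lower number from compound 2 to compound 3 (0.10 log units; within the scatter). None of them moved the number beyond the scatter, even though the groups exchanged carry quite different substituents. The change to compound 4 goes further, exchanging the six-membered ring for a five-membered one, so the uncertainty is larger, but the measured steps give no reason to expect a move beyond the scatter in this assay. Compound 4 is therefore estimated to give 50 nM, with a range from 15 nM to 170 nM, which means an expected step of no change at the digits printed from compound 1 to compound 4 (within the scatter).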

Compound 4, inhibition constant: 3 nM
Compound 4: the middle estimate sits 17-fold (1.22 log units) above what was measured; the measured number lies below the stated range.
By their numbers in this assay, from the lowest: compound 4; then compounds 3, 1 and 2 (each within the scatter of the next).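

In this assay, the aromatic group on this carbon can matter a great deal: swapping 3-hydroxyphenyl for 5-sulfamoylthiophen-2-yl gives a 17-fold lower number from compound 1 to compound 4 (1.22 log units; beyond the scatter) and is not an isolated comparison, since the same group gives a 17-fold lower number from compound 2 to compound 4 (1.22 log units; beyond the scatter) and also a 13-fold lower number from compound 3 to compound 4 (1.12 log units; beyond the scatter) in the same direction. The flat picture from compounds 1, 2 and 3 therefore held only among those three phenyl groups and did not extend to this thiophene-based group, which sets compound 4 apart from each of them by more than the scatter. Nothing measured in these compounds accounts for the improvement.

This single step changes two things at once, the ring and the sulfamoyl group on it, so the compounds shown cannot say which of them matters, or whether both are needed. A plain thiophen-2-yl group, a 4-sulfamoylphenyl group, or a thiophene carrying a carboxylic acid or a methylsulfonyl group in place of the sulfamoyl group would separate these contributions.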